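The source may report more compounds than this note shows. Statements on the series, on what has been measured and on what is new or still open speak of the compounds shown alone.

Within the data shown here, in a functional assay on HCT-116 cells (Homo sapiens) for antiproliferative activity, read by MTT assay, with a stated time of 72 h (a higher number here means a weaker inhibitor, a lower number a stronger inhibitor), compound 1 (`C=CC/N=C1\S/C(=C\c2ccc(OC)cc2)C(=O)N1C`) gives 79300 nM as the highest number so far. Compound 2 (`COc1ccc(/C=C2/CN(C)/C(=N/c3ccc(C)cc3)S2)cc1`) gives 11100 nM and compound 3 (`COc1ccc(/C=C2/CN(C)/C(=N/c3ccc(C(F)(F)F)cc3)S2)cc1`) gives 34300 nM to complete the measured set. Compound 3 therefore holds the middle place of the three numbers, closer to compound 1 than to compound 2, with both gaps beyond the scatter.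

The next compound is compound 4 (`COc1ccc(/C=C2/CN(C)/C(=N/c3ccc(Cl)cc3)S2)cc1`), which carries chloro in place of trifluoromethyl on an aromatic carbon. Among the measured compounds shown here, one measured step bears on this change: a 3.1-fold higher number from compound 2 to compound 3 (0.49 log units; beyond the scatter) when trifluoromethyl takes the place of methyl on an aromatic carbon. That step is modest but beyond the scatter. For the measured compounds named here, no measured step connects compound 1 to this change, and no measured compound in the set carries chloro on this aromatic ring.

With trifluoromethyl leaving, part of a 3.1-fold higher number from compound 2 to compound 3 (0.49 log units; beyond the scatter) is expected to be given back, although this rests on a single step. The expected move is a 1.7-fold lower number from compound 3 to compound 4 (0.23 log units; within the scatter) in this assay as a shift toward a lower number that stays within the scatter. For compound 4 the estimated value is 20000 nM with 9000 nM to 45000 nM as the expected range.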

Compound 4, half-maximal inhibitory concentration: 9800 nM
Compound 4: middle estimate off by 2.0-fold (0.31 log units), on the high side; low and high end bracket the measured number.
By their numbers in this assay, from the lowest: compounds 4 and 2 (each within the scatter of the next); then compound 3; then compound 1.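

In this assay, chloro in place of trifluoromethyl on this aromatic carbon, para to a large group, gives a 3.5-fold lower number from compound 3 to compound 4 (0.54 log units; beyond the scatter), a second step at this position and the first that starts from trifluoromethyl and goes to a group other than methyl. Chloro in place of methyl gives a 1.1-fold lower number from compound 2 to compound 4 (0.05 log units; within the scatter), so chloro and methyl cannot be told apart here, and among compound 2, compound 3 and compound 4 only the trifluoromethyl compound stands apart, with the full gap recovered rather than part of it. The pattern rests on these three compounds alone, and no measurement at hand accounts for why trifluoromethyl separates from the other two groups.

What the compounds shown leave open is how far this position extends beyond these three groups: a methoxy, a nitrile, an amine or a carboxylic acid on the same aromatic carbon would test whether trifluoromethyl is a lone exception or one end of a wider spread. Going by these compounds, whether the same order of groups holds on the core of compound 1, which carries an allyl chain in place of the substituted aromatic ring, also stays open.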